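Tetrazole to chlorotriazole swap on the compound 2 scaffold

The compounds below may be only part of what the source reports. "The series", "measured", "known", "first", "only" and "open" are said of these compounds alone.

Measured in an ADME assay on a cell-free system (plasma, Homo sapiens) for protein binding:
- compound 1 `Cn1nncc1-c1cnn([C@H](CC2CC2)c2ccc(-c3c(-n4cnnn4)ccc(Cl)c3F)c[n+]2[O-])c1` gives 80.9%
- compound 2 `COCC[C@H](c1ccc(-c2c(-n3cnnn3)ccc(Cl)c2F)c[n+]1[O-])n1cc(-c2cnnn2C)cn1` gives 67.1%
- compound 3 `Cn1nncc1-c1cnn([C@H](CCOC(F)F)c2ccc(-c3c(-n4cnnn4)ccc(Cl)c3F)c[n+]2[O-])c1` gives 83.6%

Compound 2 stands within the scatter of both other compounds, with a 1.7-fold higher unbound fraction from compound 1 to compound 2 (0.24 log units; within the scatter) on one side and a 2.0-fold lower unbound fraction from compound 2 to compound 3 (0.30 log units; within the scatter) on the other.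

Next is compound 4 `COCC[C@H](c1ccc(-c2c(-n3cc(Cl)nn3)ccc(Cl)c2F)c[n+]1[O-])n1cc(-c2cnnn2C)cn1` which keeps the core and chain of compound 2 and alters one group. The change is 4-chloro-1H-1,2,3-triazol-1-yl in place of 1H-tetrazol-1-yl on an aromatic carbon on an aromatic carbon of a six-membered aromatic ring of carbon only, ortho to a large group, meta to a fluoro group and para to a chloro group.

For the measured compounds named here, no measured step touches this place. All three lie on the saturated chain, and a 1.2-fold lower unbound fraction from compound 1 to compound 3 (0.07 log units; within the scatter) also stays within the scatter, so they offer only a rough scale for the new step. With a chlorinated triazolyl group entering, a modest shift towards more binding is expected from compound 2 at 67.1% but without direct precedent in the series. The expected change is a 1.6-fold lower unbound fraction from compound 2 to compound 4 (0.22 log units; within the scatter) and it is an estimate only. For compound 4 the estimated value is 80% with an expected range from 68% to 90% in this assay for now.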

Compound 4, plasma protein binding: 86%
Compound 4: the middle estimate sits 1.4-fold (0.15 log units) (unbound fraction) above what was measured, within the range that was stated.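

In this assay, 4-chloro-1H-1,2,3-triazol-1-yl in place of 1H-tetrazol-1-yl on the aromatic carbon gives a 2.4-fold lower unbound fraction from compound 2 to compound 4 (0.37 log units; beyond the scatter), the only step shown that lies beyond the scatter. This place, ortho to a large group, meta to a fluoro group and para to a chloro group, therefore affects plasma protein binding measurably, whereas the steps among the chain variants compound 1, compound 2 and compound 3 all stay within the scatter. Two things change at once in this step, a ring with 4 hetero atoms giving way to one with 3 and a chlorine entering, and nothing shown explains the shift or divides it between them.

A 1H-1,2,3-triazol-1-yl group without the chlorine, or one carrying a methyl group or a nitrile in its place, would show how much of the step belongs to the chlorine and how much to the ring. Also open, going by these compounds, is whether the same exchange gives a step of similar size on the cyclopropyl chain of compound 1 or the difluoromethoxy chain of compound 3.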